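From methylsulfanyl to propoxy at the assay limit

The source may hold more compounds than are shown below. What is called first, only, known or untested is meant among the compounds shown, and "the series" means these compounds.

Measured in an ADME assay on BCBL1 cells (Homo sapiens) for cytotoxicity, with a stated time of 7 days; a lower number here means that less compound is tolerated, a higher number that more compound is tolerated:
compound 1 `CC(C)CSc1nc(N)nc2c1ncn2/C=C1/CC1(CO)CO`: > 20000 nM
compound 2 `C=CCOc1nc(N)nc2c1ncn2/C=C1/CC1(CO)CO`: > 20000 nM
compound 3 `CSc1nc(N)nc2c1ncn2/C=C1/CC1(CO)CO`: > 20000 nM

In this assay compound 3 gives > 20000 nM, which is a limit of the assay and not a number. It has company, because the whole set stands at the limit of > 20000 nM in this assay, at which 3 of the 3 values shown sit.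

The next compound is compound 4 `CCCOc1nc(N)nc2c1ncn2/C=C1/CC1(CO)CO`, which keeps the shared core and changes one group: propoxy in place of methylsulfanyl on an aromatic carbon. In words, this is propoxy in place of methylsulfanyl on an aromatic carbon, next to the ring nitrogen.

Going by the values given here, three measured steps bear on this change. The closest is a step that the two limits leave unreadable from compound 2 to compound 3, since it also swaps methylsulfanyl for a different group at this place. The other two are a step that the two limits leave unreadable from compound 1 to compound 2 and a step that the two limits leave unreadable from compound 1 to compound 3. Among the compounds with values here, none of them has a readable size, so they can only show that no compound has yet left the limit.

Compound 2 carries allyloxy, the measured group most like propoxy, and gives > 20000 nM, again a limit. On that basis, no step beyond the usual scatter is expected, and no direction can be given. The expected step is a number no higher from compound 3 to compound 4 (the limit leaves the size open). Another limit is the most likely report. In this assay the estimated value for compound 4 is 20000 nM, with an expected range of 10000 nM to 40000 nM.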

Compound 4, half-maximal cytotoxic concentration: > 20000 nM
Compound 4 gave a limit, no number (the forecaster's own chance of this, stated with the estimate: 85%); the middle value sits exactly at the limit.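

In this assay compound 4 gives > 20000 nM, which is a limit of the assay and not a number, so its steps to compound 1, compound 2 and compound 3 cannot be read. All the compounds shown share one result: the limit of > 20000 nM in this assay, at which 4 of the 4 values shown sit.

They leave open how much of any of these compounds the cells tolerate, and whether changing this group alters that at all.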